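A few compounds are considered here, and "the series" means these few. Any claim that something is new, unique, unknown or untested is made for them only; others in the source may bear on it.

Three compounds sharing one core have numbers in a functional assay on PC-3 cells (Homo sapiens) for antiproliferative activity, read by MTT assay, with a stated time of 48 h; on this read-out lower numbers stand for stronger inhibition and higher numbers for weaker inhibition. There, compound 1 `CCn1c(C(=O)NCCN(C)C)ccc1C(CC)(CC)c1ccc(OCCC(O)(CC)CC)c(C)c1` gives 870 nM, compound 2 `C#CC(C)OC(=O)c1ccc(C(CC)(CC)c2ccc(OCCC(O)(CC)CC)c(C)c2)n1CC` gives 14800 nM, and compound 3 `CCn1c(C(=O)Nc2cccc(C(F)(F)F)c2)ccc1C(CC)(CC)c1ccc(OCCC(O)(CC)CC)c(C)c1` gives 23800 nM. Compound 3 thus shares the weak end of this small set with compound 2. The gap seen in a 1.6-fold higher number from compound 2 to compound 3 (0.21 log units; within the scatter) lies within the scatter, while a 27-fold higher number from compound 1 to compound 3 (1.44 log units; beyond the scatter) is large.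

Compound 4 `CCOc1ccc(NC(=O)c2ccc(C(CC)(CC)c3ccc(OCCC(O)(CC)CC)c(C)c3)n2CC)cc1` keeps the core and the amide but carries 4-ethoxyphenyl in place of 3-(trifluoromethyl)phenyl on the amide-type nitrogen (4-ethoxyphenyl in place of 3-(trifluoromethyl)phenyl on an amide-type nitrogen). For the measured compounds named here, no measured step swaps one aromatic group for another at this place. The two large steps, a 17-fold higher number from compound 1 to compound 2 (1.23 log units; beyond the scatter) and a 27-fold higher number from compound 1 to compound 3 (1.44 log units; beyond the scatter), both replace a side chain that compound 4 lacks too, so they offer little guide. Going by the values given here, the one step without that side chain, a 1.6-fold higher number from compound 2 to compound 3 (0.21 log units; within the scatter), stays within the scatter. In this assay, then, no change beyond the scatter is expected, and no firm direction. The estimated step is a 1.3-fold lower number from compound 3 to compound 4 (0.12 log units; within the scatter). Compound 4 is expected at about 18000 nM, with an estimated range of 6000 nM to 45000 nM.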

Compound 4, half-maximal inhibitory concentration: > 50000 nM
Compound 4 was reported as a limit; the forecaster's own chance of this, stated with the estimate: 10%; at least 2.7-fold (0.44 log units) between middle value and limit.
By their numbers in this assay, from the lowest: compound 1; then compounds 2 and 3 (each within the scatter of the next). At a limit, above all of these: compound 4.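

In this assay, compound 4 has no exact number, only a limit of the assay: the limit of > 50000 nM in this assay, at which 1 of the 4 values shown sits. For the compounds shown here, no earlier step swapped one aromatic group for another on the amide-type nitrogen, and this swap gives an at least 2.1-fold higher number from compound 3 to compound 4 (0.32 log units; beyond the scatter), so the two aromatic groups are not interchangeable here. The other comparisons read an at least 3.3-fold higher number from compound 2 to compound 4 (0.52 log units; beyond the scatter) and an at least 57-fold higher number from compound 1 to compound 4 (1.75 log units; beyond the scatter), which shows that 4-ethoxyphenyl, unlike 3-(trifluoromethyl)phenyl, separates from the ester of compound 2 and lies further still from the 2-(dimethylamino)ethyl chain of compound 1.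

Going by these compounds, the true size of these steps stays open, as a limit sets only a bound. Also open, on these data alone, is how a plain phenyl ring, or a longer amine chain such as 3-(dimethylamino)propyl, would behave on the same amide-type nitrogen.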